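Moving the Methyl Groups on the Aryl Ring

This account rests on a few compounds, and the source may have more. Where it says the series, first, only, none or still open, it means among the compounds named here.

The series shares one core and varies only the aryl group attached to it. Compound 1 `CCCc1ccc(-c2cc(=O)c3c(o2)C(CC)(CC)C(=O)C(CC)=C3O)cc1` carries a 4-propylphenyl group; in a functional assay on KB cells (Homo sapiens) for antiproliferative activity, read by sulforhodamine B assay, with a stated time of 3 days (on this read-out higher numbers stand for an effect only at larger amounts of compound and lower numbers for an effect already at smaller amounts), compound 1 gives only a limit, > 53 uM, as recorded in the limit of > 53 uM in this assay, at which 1 of the 3 values shown sits. Compound 2 `CCC1=C(O)c2c(oc(-c3ccccc3OC)cc2=O)C(CC)(CC)C1=O` carries a 2-methoxyphenyl group, and in this assay compound 2 gives 40.8 uM. Compound 3 `CCC1=C(O)c2c(oc(-c3ccc(C)cc3C)cc2=O)C(CC)(CC)C1=O` carries a 2,4-dimethylphenyl group, and in this assay compound 3 gives 41.2 uM. Compound 3 thus stands together with compound 2, the step of a 1.0-fold higher number from compound 2 to compound 3 (0.00 log units; within the scatter) lying within the scatter, while the steps of an at least 1.2-fold lower number from compound 1 to compound 2 (0.11 log units; that floor lies within the scatter) and an at least 1.2-fold lower number from compound 1 to compound 3 (0.10 log units; that floor lies within the scatter) start from a limit and fix only a floor.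

The untested compound 4 `CCC1=C(O)c2c(oc(-c3cc(C)cc(C)c3)cc2=O)C(CC)(CC)C1=O` differs from compound 3 by 3,5-dimethylphenyl in place of 2,4-dimethylphenyl on an aromatic carbon. Going by the values given here, the one measured step that exchanges one substituted phenyl for another, a 1.0-fold higher number from compound 2 to compound 3 (0.00 log units; within the scatter), moved nothing beyond the scatter, so a step of similar size, in no clear direction, is expected in this assay. Compound 4 is therefore estimated at 40 uM, within 20 uM to 80 uM. The step this estimate implies, a 1.0-fold lower number from compound 3 to compound 4 (0.01 log units; within the scatter), is expected to stay within the scatter.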

Compound 4, concentration for half-maximal effect: 45.5 uM
For compound 4 the middle estimate is 1.1-fold (0.06 log units) below the measured one; low and high end bracket the measured number.
By their numbers in this assay, from the lowest: compounds 2, 3 and 4 (each within the scatter of the next). At a limit, above all of these: compound 1.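

Going by these compounds alone, exchanging the 2,4-dimethylphenyl group for the 3,5-dimethylphenyl group changes only where the two methyl groups sit on the phenyl ring, a kind of change the earlier compounds did not offer, and in this assay it gives a 1.1-fold higher number from compound 3 to compound 4 (0.04 log units; within the scatter). The 3,5-dimethylphenyl group also shows no separation from the 2-methoxyphenyl group, with a 1.1-fold higher number from compound 2 to compound 4 (0.05 log units; within the scatter), so in this small set neither the placement of the methyl groups nor the exchange of these two substituted phenyl groups is seen to move the number beyond the scatter. The comparison with the 4-propylphenyl group stays unresolved, as an at least 1.1-fold lower number from compound 1 to compound 4 (0.06 log units; that floor lies within the scatter) fixes only a floor and compound 1 is recorded only as a limit: the limit of > 53 uM in this assay, at which 1 of the 4 values shown sits.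

The compounds shown leave open whether any group at this position can move the number beyond the scatter, as the measured groups are limited to phenyl rings carrying methyl, methoxy or propyl. Also open, on these data alone, is how the number would respond to an amine or a carboxylic acid on the phenyl ring, or to a longer chain in place of the ethyl groups on the shared core.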